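The source may report more compounds than this note shows. Statements on the series, on what has been measured and on what is new or still open speak of the compounds shown alone.

Measured compounds:
compound 1 `Cc1c(-c2cc(Cl)cc(Cl)c2)c(C(=O)O)nn1-c1nc(-c2cc(Cl)cc(Cl)c2)c(SC(C)C)s1`, 2000 nM
compound 2 `CC(=O)Nc1ccc(-c2c(C)nn(-c3nc(-c4ccc(Cl)c(Cl)c4)c(SC(C)C)s3)c2C(=O)O)cc1`, 139000 nM
compound 3 `Cc1c(-c2cc(Cl)cc(Cl)c2)c(C(=O)O)nn1-c1nc(-c2ccncc2)c(SC(C)C)s1`, "not active" (no number reported)

The study concerns antiproliferative activity assessed in a functional assay on BJAB cells (Homo sapiens) for antiproliferative activity, with a stated time of 4 days; on this read-out lower numbers stand for an effect already at smaller amounts and higher numbers for an effect only at larger amounts of compound. Among the compounds that gave a number, compound 2 stands highest: in this assay compound 2 gives 139000 nM, whereas compound 1 gives 2000 nM, a gap well beyond the scatter of this kind of measurement. Compound 3 is reported without a number, as "not active" (no number reported).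

Compound 4 `Cc1nn(-c2nc(-c3ccc(Cl)c(Cl)c3)c(SC(C)C)s2)c(C(=O)O)c1-c1ccccc1Cl` has not yet been measured. It differs from compound 2 in one place: 2-chlorophenyl in place of 4-acetamidophenyl on an aromatic carbon. For the measured compounds named here, no step between measured compounds tells directly how such an exchange plays out, so the expectation rests on where compound 2 stands relative to compound 1. Since compound 1 with its dichlorophenyl groups gives 2000 nM while compound 2 gives 139000 nM, a sizeable step toward a lower number is expected for compound 4, though short of compound 1. The step from compound 2 to compound 4 is estimated as a 14-fold lower number from compound 2 to compound 4 (1.14 log units; beyond the scatter). Compound 4 is accordingly expected to give about 10000 nM, within a range of 2000 nM to 50000 nM.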

Compound 4, half-maximal effective concentration: 13100 nM
Compound 4: middle estimate off by 1.3-fold (0.12 log units), on the low side, and the stated range covers the measured number.
By their numbers in this assay, from the lowest: compound 1; then compound 4; then compound 2.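

In this assay, for the compounds shown here, placing 2-chlorophenyl in place of 4-acetamidophenyl on this aromatic carbon, which lies next to the ring atoms bearing the carboxy and methyl groups, gives an 11-fold lower number from compound 2 to compound 4 (1.03 log units; beyond the scatter), the first direct reading of this position, since no earlier pair of compounds differed in one place. The step shows that the number responds strongly to the group at this carbon while the rest of the molecule stays the same, but the exchange removes the acetamido part with its hydrogen-bond donor and acceptor and also brings in a chlorine, and this single step cannot separate those changes. Nothing available on these compounds accounts for the size of the step.

The compounds shown leave open how an unsubstituted phenyl ring, or a phenyl ring carrying an amine or a methoxy group, would read at this position, and so whether the chlorine contributes at all or the loss of the acetamido part alone is enough. They also leave open whether the same exchange would give a step of similar size on the core of compound 1.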